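Tetrazole Series at the Assay Limit: Compound 4 Expected

This account rests on a few compounds, and the source may have more. Where it says the series, first, only, none or still open, it means among the compounds named here.

compound 1 `CC(C)(N)C(=O)N[C@H](COCc1ccccc1)c1nnnn1Cc1ccc(NS(C)(=O)=O)cc1`: > 5000 nM
compound 2 `CC(C)(N)C(=O)N[C@H](COCc1ccccc1)c1nnn(Cc2ccc(NS(C)(=O)=O)cc2)n1`: > 5000 nM
compound 3 `CC(C)(N)C(=O)N[C@H](COCc1ccccc1)c1nnn(CC#N)n1`: > 5000 nM

In an assay on isolated protein for displacement of a labelled ligand from growth hormone secretagogue receptor type 1 (Homo sapiens), with a stated time of 1 h (on this read-out lower numbers stand for stronger inhibition and higher numbers for weaker inhibition), compound 1 gives > 5000 nM, which is a limit of the assay and not a number. Compound 2 likewise reaches only a limit, > 5000 nM. Compound 3 also stops at a limit, > 5000 nM. All three values sit at the limit of > 5000 nM in this assay, at which 3 of the 3 values shown sit, so compound 1 cannot be ranked against the others. Within the data shown here, the only measured step is the one from compound 2 to compound 3, a step that the two limits leave unreadable from compound 2 to compound 3, and it is unreadable. Compound 4 `COC(=O)CCCn1nnnc1[C@@H](COCc1ccccc1)NC(=O)C(C)(C)N` differs from compound 1 by 2-(methoxycarbonyl)ethyl in place of 4-(methanesulfonamido)phenyl on a saturated chain carbon bound to an aromatic nitrogen. With every value at the limit, no direction can be read from the measured step. Compound 4 is expected to remain near the limit, with a step that the limit leaves unreadable from compound 1 to compound 4. Compound 4 is therefore estimated at 6000 nM, between 1500 nM and 25000 nM.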

Compound 4, inhibition constant: 2380 nM
Compound 4: middle estimate off by 2.5-fold (0.40 log units), on the high side, within the range that was stated.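

In this assay, 2-(methoxycarbonyl)ethyl in place of 4-(methanesulfonamido)phenyl on a saturated chain carbon bound to an aromatic nitrogen gives an at least 2.1-fold lower number from compound 1 to compound 4 (0.32 log units; beyond the scatter). Among these compounds, this is the first readable step at this position, as the earlier step cannot be read, and it shows that a group with no ring can lift the read-out off the limit. Its full size stays unknown, as most values remain limits: the limit of > 5000 nM in this assay, at which 3 of the 4 values shown sit.

Going by these compounds, whether a carboxylic acid, an amine or a longer chain in place of 2-(methoxycarbonyl)ethyl would lower the number further remains open.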